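A few compounds are considered here, and "the series" means these few. Any claim that something is new, unique, unknown or untested is made for them only; others in the source may bear on it.

Compound 1 `Cc1cc(Oc2ccc(Cn3nc4ccc(Cl)cc4c3C(=O)NS(=O)(=O)c3ccc(NCc4cccnc4)c([N+](=O)[O-])c3)cc2)cc(C)c1Cl`: 1180 nM in an assay on isolated protein for inhibition of Apoptosis regulator Bcl-2 (Homo sapiens), read by fluorescence polarization; a higher number here means a weaker inhibitor, a lower number a stronger inhibitor
Compound 2 `Cc1cc(Oc2ccc(Cn3nc4ccc(Cl)cc4c3C(=O)NS(=O)(=O)c3ccc(NCc4ccncc4)c([N+](=O)[O-])c3)cc2)cc(C)c1Cl`: 1520 nM in this assay
Compound 3 `Cc1cc(Oc2ccc(Cn3nc4ccc(Cl)cc4c3C(=O)NS(=O)(=O)c3ccc([N+](=O)[O-])c(NCc4ccn(C)n4)c3)cc2)cc(C)c1Cl`: 710 nM in this assay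

Compound 3 and compound 1 give numbers within the usual scatter of each other, while the number for compound 2 lies beyond the scatter above that of compound 3. Compound 4 `Cc1cc(Oc2ccc(Cn3nc4ccc(Cl)cc4c3C(=O)NS(=O)(=O)c3ccc([N+](=O)[O-])c(NCc4ccncc4)c3)cc2)cc(C)c1Cl` differs from compound 3 by pyridin-4-yl in place of 1-methyl-1H-pyrazol-3-yl on a saturated chain carbon bound to a nitrogen on an aromatic ring. Among the compounds with values here, the only measured step of a related kind is a 1.3-fold higher number from compound 1 to compound 2 (0.11 log units; within the scatter), which exchanges one six-membered ring for another and stays within the scatter. Within the data shown here, no measured step exchanges a five-membered ring for a six-membered one; compound 2, which carries the same pyridin-4-yl group as compound 4 but is not a single-change neighbour of compound 3, sits beyond the scatter above compound 3. A modest rise is therefore expected, a 1.5-fold higher number from compound 3 to compound 4 (0.19 log units; within the scatter). Compound 4 is estimated at 1100 nM, with a range from 500 nM to 2500 nM.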

Compound 4, inhibition constant: 710 nM
Compound 4: middle estimate off by 1.5-fold (0.19 log units), on the high side; measured number inside the range.
By their numbers in this assay, from the lowest: compounds 3, 4, 1 and 2 (each within the scatter of the next, the first and the last beyond it).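

Putting pyridin-4-yl in place of 1-methyl-1H-pyrazol-3-yl gives no change at the digits printed from compound 3 to compound 4 (within the scatter) in this assay. This is the first step shown that exchanges a five-membered aromatic ring for a six-membered one on a saturated chain carbon bound to a nitrogen on an aromatic ring, and the reading does not move despite the different ring size and hetero atom count. No available measurement offers an explanation for this result. Still open, from the compounds shown here alone, is whether a morpholine, or an amine on a longer chain, would leave the number just as unmoved.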